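The compounds below may be only part of what the source reports. "The series", "measured", "known", "first", "only" and "open" are said of these compounds alone.

Compound 2 `CC1CCN(c2nc(C(F)(F)F)ccc2CNC(=O)C(c2ccccc2)c2ccc(NS(C)(=O)=O)c(F)c2)CC1` stands lowest of the two numbers in an assay on CHO cells for antagonist activity at transient receptor potential cation channel subfamily V member 1 (Homo sapiens), read by FLIPR (on this read-out lower numbers stand for stronger inhibition and higher numbers for weaker inhibition), where compound 2 gives 1.3 nM. Compound 3 `CS(=O)(=O)Nc1ccc(C(C(=O)NCc2ccc(C(F)(F)F)nc2SC2CCCCC2)c2cccc(F)c2)cc1F` gives 48.7 nM in this assay, a gap from compound 2 that lies beyond the scatter. Compound 1 `CS(=O)(=O)Nc1ccc(C(C(=O)NCc2ccc(C(F)(F)F)nc2SC2CCCCC2)C2CCCCC2)cc1F` is recorded in this assay only as "active" (no number reported), without a number. Compound 4 `Cc1cccc(C(C(=O)NCc2ccc(C(F)(F)F)nc2N2CCC(C)CC2)c2ccc(NS(C)(=O)=O)c(F)c2)c1` has not yet been measured. It differs from compound 2 by methyl in place of hydrogen on an aromatic carbon. Within the data shown here, no step between measured compounds covers this change, so the expectation rests on compound 2 alone. The step is estimated as a 1.5-fold higher number from compound 2 to compound 4 (0.19 log units; within the scatter), small and not beyond the scatter in either direction. Compound 4 is therefore expected to give about 2 nM in this assay, within a range from 0.6 nM to 8 nM.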

Compound 4, inhibition constant: 0.1 nM
Compound 4: middle estimate off by 20-fold (1.30 log units), on the high side, and the stated range ends above it.
By their numbers in this assay, from the lowest: compound 4; then compound 2; then compound 3.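

In this assay the change from phenyl to 3-methylphenyl gives a 13-fold lower number from compound 2 to compound 4 (1.11 log units; beyond the scatter) and so shows that this aromatic carbon, meta to a large group, is not indifferent to substitution. A single added methyl is enough to move the number beyond the scatter, which compound 2 alone could not show. No measurement here accounts for this step. The compounds shown leave open whether an ethyl group, a methoxy group or a chlorine atom at this place would give a similar step. They also leave open whether methyl on another carbon of this ring would do the same.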